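The source may report more compounds than this note shows. Statements on the series, on what has been measured and on what is new or still open speak of the compounds shown alone.

Compound 1, `COc1cc2c(cc1NS(=O)(=O)c1cccc(Cl)c1Cl)[nH]c(=O)n2C`: 12 ug/mL
Compound 2, `COc1cc2c(cc1NS(=O)(=O)c1cccc(Cl)c1Cl)[nH]c(=O)n2C(C)C`: 3 ug/mL

In a physicochemical assay for solubility, read by chemiluminescence, measured as kinetic solubility (a lower number here means a less soluble compound, a higher number a more soluble compound), compound 1 gives 12 ug/mL, the highest of the two numbers. Its nearest neighbour is compound 2, which gives 3 ug/mL, so that a 4.0-fold lower number from compound 1 to compound 2 (0.60 log units; beyond the scatter).

Compound 3, `COc1cc2c(cc1NS(=O)(=O)c1cccc(Cl)c1Cl)[nH]c(=O)n2C(CO)CO`, is not yet measured. It differs from compound 1 by 2-hydroxy-1-(hydroxymethyl)ethyl in place of methyl on an aromatic nitrogen. Going by the values given here, the only measured step bears on the same aromatic nitrogen but runs in the opposite kind of substitution, so it gives no direct match; on the structural change alone a step upward in this assay is expected, a 3.3-fold higher number from compound 1 to compound 3 (0.52 log units; beyond the scatter). Compound 3 is therefore estimated at 40 ug/mL, with a range from 15 ug/mL to 120 ug/mL.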

Compound 3, solubility: 82 ug/mL
Compound 3: middle estimate off by 2.1-fold (0.31 log units), on the low side; low and high end bracket the measured number.
By their numbers in this assay, from the lowest: compound 2; then compound 1; then compound 3.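

On the aromatic nitrogen, 2-hydroxy-1-(hydroxymethyl)ethyl gives the first upward move in this assay (a 6.8-fold higher number from compound 1 to compound 3 (0.83 log units; beyond the scatter)), so the number at this position can go either way from methyl. Measured against isopropyl, the same group gives a large step (a 27-fold higher number from compound 2 to compound 3 (1.44 log units; beyond the scatter)), and the three compounds span a wide range through this one position alone. Nothing measured here accounts for these steps.

Still open, on these data alone, is whether a 2-hydroxyethyl chain, an amine or a carboxylic acid on this nitrogen would reach a similar number. The data also leave open how the two hydroxyl groups of this substituent contribute individually.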